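Swapping the Aniline Substituent on a Weakly Active Core

The source may hold more compounds than are shown below. What is called first, only, known or untested is meant among the compounds shown, and "the series" means these compounds.

Two compounds share one core and differ only in the group on the aromatic nitrogen. Compound 1 `N[C@H]1CCc2nc(-c3ccncc3)nc(Nc3cccc(F)c3)c2C1` in a functional assay on MCF7 cells (Homo sapiens) for antiproliferative activity, read by MTT assay, with a stated time of 72 h (a higher number here means a weaker inhibitor, a lower number a stronger inhibitor), gives 14200 nM. Compound 2 `CN(C)c1ccc(Nc2nc(-c3ccncc3)nc3c2CC(N)CC3)cc1` in this assay gives 15800 nM, the higher number of the two, though its gap to compound 1 falls within the scatter. Compound 3 `COc1cccc(Nc2nc(-c3ccncc3)nc3c2CC(N)CC3)c1` carries 3-methoxyphenyl in place of 4-(dimethylamino)phenyl on a nitrogen on an aromatic ring. Among the measured compounds shown here, no measured step of this kind exists between the two compounds, so no change beyond the scatter is expected in this assay. Compound 3 is expected to give 14000 nM in this assay, within a range from 5000 nM to 40000 nM. This estimate means a step of a 1.1-fold lower number from compound 2 to compound 3 (0.05 log units; within the scatter) that stays within the scatter.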

Compound 3, half-maximal inhibitory concentration in the MCF7 assay: 15800 nM
For compound 3 the middle estimate is 1.1-fold (0.05 log units) below the measured one; the range from low to high includes it.
By their numbers in the MCF7 assay, from the lowest: compounds 1, 2 and 3 (each within the scatter of the next).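

In the MCF7 assay, 3-methoxyphenyl in place of 4-(dimethylamino)phenyl on a nitrogen on an aromatic ring gives no change at the digits printed from compound 2 to compound 3 (within the scatter), so this first measured step at this position leaves the number unchanged. In a physicochemical assay for solubility, read by HPLC, in phosphate buffer, measured as kinetic solubility, with a stated time of 24 h, at pH 7.4 (on this read-out lower numbers stand for lower solubility and higher numbers for higher solubility), compound 2 gives > 250000 nM, which is a limit of the assay and not a number. In the physicochemical assay compound 3 gives > 250000 nM, also a limit, so the step between these two cannot be read.

On these data alone, it remains open whether a carboxylic acid or a morpholine ring on the phenyl group would move the number in the MCF7 assay.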